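Working notes on compound 3 ahead of its measurement

This account rests on a few compounds, and the source may have more. Where it says the series, first, only, none or still open, it means among the compounds named here.

Measured so far:
compound 1, `C=C1C(=O)[C@]23C[C@@]1(O)CC[C@H]2c1ccc(O)c(C)c1[C@@H]3Cn1cc(-c2ccccc2)nn1`, gives 1320 nM in a functional assay on SMMC-7721 cells (Homo sapiens) for cytotoxicity, read by MTT assay, with a stated time of 4 days; a higher number here means a weaker inhibitor, a lower number a stronger inhibitor.
compound 2, `C=C1C(=O)[C@]23C[C@@]1(O)CC[C@H]2c1ccc(O)c(C)c1[C@@H]3Cn1cc(-c2ccc(C(F)(F)F)cc2)nn1`, gives 1440 nM in this assay.

Compound 2 stands together with compound 1 at the upper end of these two numbers; the step of a 1.1-fold higher number from compound 1 to compound 2 (0.04 log units; within the scatter) lies within the scatter. Compound 3, `C=C1C(=O)[C@]23C[C@@]1(O)CC[C@H]2c1ccc(O)c(C)c1[C@@H]3Cn1cc(-c2ccc(C)cc2)nn1`, differs from compound 2 by methyl in place of trifluoromethyl on an aromatic carbon. For the measured compounds named here, the only measured step that bears on this position is a 1.1-fold higher number from compound 1 to compound 2 (0.04 log units; within the scatter), a change at the same aromatic carbon that stayed within the scatter. A further swap there is therefore expected to move this assay by nothing beyond the scatter, in no set direction. Compound 3 is expected to give 1400 nM, range 700 nM to 2800 nM, an expected step of a 1.0-fold lower number from compound 2 to compound 3 (0.01 log units; within the scatter).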

Compound 3, half-maximal inhibitory concentration: 920 nM
Compound 3: the middle estimate sits 1.5-fold (0.18 log units) above what was measured; the measured number falls inside the stated range.
By their numbers in this assay, from the lowest: compounds 3, 1 and 2 (each within the scatter of the next).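

In this assay, the aromatic carbon para to a large group has now held hydrogen, trifluoromethyl and methyl, and both new steps stay within the scatter (a 1.6-fold lower number from compound 2 to compound 3 (0.19 log units; within the scatter); a 1.4-fold lower number from compound 1 to compound 3 (0.16 log units; within the scatter)). The earlier compounds shown here gave one swap at this carbon; with methyl there are three, and none separates from the others. No measurement here accounts for these readings.

Going by these compounds, an amine, a carboxylic acid or a longer chain at this carbon remains open. So does whether a change in the shared core would move the number beyond the scatter.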